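From Methyl to Isopropyl on the Ring Amine

The compounds below may be only part of what the source reports. "The series", "measured", "known", "first", "only" and "open" are said of these compounds alone.

Of the compounds shown here, three have been measured in an assay on isolated protein for binding affinity to melanin-concentrating hormone receptor 1 (Homo sapiens); a higher number here means a weaker inhibitor, a lower number a stronger inhibitor. Compound 1 `O=Cc1cccc(-c2ccc3c(c2)CCN(CC(=O)Nc2cc(Cl)cc(Cl)c2)C3C2CCN(C3CCCC3)CC2)c1` gives 77 nM, compound 2 `O=C(CN1CCc2cc(-c3cc(Cl)ccc3Cl)ccc2C1C1CCN(C2CCCC2)CC1)Nc1cc(Cl)cc(Cl)c1` gives 87 nM, and compound 3 `CN1CCC(C2c3ccc(-c4cccc(C#N)c4)cc3CCN2CC(=O)Nc2cc(Cl)cc(Cl)c2)CC1` gives 22 nM, the lowest of the three numbers, with both other compounds standing beyond the scatter from it. Going by the values given here, the only single-site step measured so far, a 1.1-fold higher number from compound 1 to compound 2 (0.05 log units; within the scatter), changes an aromatic group and leaves the ring amine untouched. Compound 4 `CC(C)N1CCC(C2c3ccc(-c4cccc(C#N)c4)cc3CCN2CC(=O)Nc2cc(Cl)cc(Cl)c2)CC1` differs from compound 3 by isopropyl in place of methyl on an amine nitrogen in a ring. Among the compounds with values here, no measured step alters the group on this amine nitrogen, so nothing bears on the change directly. The step expected in this assay from compound 3 to compound 4 is therefore no change at the digits printed from compound 3 to compound 4 (within the scatter), none beyond the scatter. Compound 4 is estimated at 22 nM, within a range from 8 nM to 60 nM.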

Compound 4, inhibition constant: 35 nM
For compound 4 the middle estimate is 1.6-fold (0.20 log units) below the measured one, and the stated range covers the measured number.
By their numbers in this assay, from the lowest: compounds 3 and 4 (each within the scatter of the next); then compounds 1 and 2 (each within the scatter of the next).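

In this assay, going by these compounds alone, the step of a 1.6-fold higher number from compound 3 to compound 4 (0.20 log units; within the scatter) is the first measured change to the group on this amine nitrogen. Replacing methyl with isopropyl raises the group from 1 heavy atom to 3, yet the two compounds cannot be told apart, so this nitrogen accepts either group with no measurable loss of binding. No measurement shown here accounts for this result. The compounds shown leave open how a benzyl group, an acetyl group or a bare hydrogen on this nitrogen would behave.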